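Ester removal on a boronate series at the assay ceiling

A few compounds are considered here, and "the series" means these few. Any claim that something is new, unique, unknown or untested is made for them only; others in the source may bear on it.

Compound 1, with the structure `COC(=O)[C@@H](N)CCB(O)O`, and compound 2, with the structure `COC(=O)[C@@H](N)CCB1O[C@@]2(C)CCC3C[C@@]2(O1)C3(C)C`, share an amino ester chain ending in a boron-bearing group. In a functional assay (on this read-out lower numbers stand for stronger inhibition and higher numbers for weaker inhibition), compound 1 gives only a limit, > 100000 nM. In this assay compound 2 likewise gives only a limit, > 100000 nM. Compound 2 therefore sits at the limit of > 100000 nM in this assay, at which 2 of the 2 values shown sit, so no ranking among the measured compounds is possible; neither shows measurable inhibition.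

Compound 3, with the structure `CC1(C)C2CC[C@]3(C)OB(CCCN)O[C@]13C2`, differs from compound 2 by one change: hydrogen in place of methoxycarbonyl on a saturated chain carbon bound to an amine nitrogen and a saturated chain carbon. The loss of the methoxycarbonyl removes the only ester in the molecule while leaving the amine and the cyclic boronate untouched.

For the measured compounds named here, with both measured compounds beyond the ceiling of this assay, no measured step is available, and the expectation for compound 3 rests only on that ceiling. The expected step from compound 2 to compound 3 is a step that the limit leaves unreadable from compound 2 to compound 3, that is, no gain beyond the scatter. Compound 3 is accordingly estimated at 150000 nM in this assay, within a range from 30000 nM to 1000000 nM, with a limit rather than a number the most likely outcome.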

Compound 3, half-maximal inhibitory concentration: > 100000 nM
Compound 3 gave a limit, no number; the forecaster's own chance of this, stated with the estimate: 80%; the middle value is on the limit's open side.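

In this assay compound 2 and compound 3 both give only limits, so the change from one to the other cannot be read as a step: the limit of > 100000 nM in this assay, at which 3 of the 3 values shown sit.

The three compounds shown leave open which structure, if any, would bring inhibition into the measurable range of this assay and whether the methoxycarbonyl group has any bearing on it.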